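The source may hold more compounds than are shown below. What is called first, only, known or untested is meant among the compounds shown, and "the series" means these compounds.

Measured in a functional assay on IMR-32 cells (Homo sapiens) for antiproliferative activity, read by MTT assay; a higher number here means a weaker inhibitor, a lower number a stronger inhibitor:
Compound 1 `CCc1ccccc1-n1cc(COc2ccc(/C=C/C(=O)c3cc4c(cc3O)OC(C)(C)CC4)cc2)nn1` gives "not active" (no number reported)
Compound 2 `CC1(C)CCc2c(ccc(C(=O)/C=C/c3ccc(OCc4cn(-c5ccc(Br)cc5)nn4)cc3)c2O)O1` gives 117000 nM

Of these two, only compound 2 has a number, so it cannot yet be ranked against anything. Compound 3 `CC(=O)c1ccc(-n2cc(COc3ccc(/C=C/C(=O)c4ccc5c(c4O)CCC(C)(C)O5)cc3)nn2)cc1` has not been measured. It carries acetyl in place of bromo on an aromatic carbon, para to a large group, turning 4-bromophenyl into 4-acetylphenyl (acetyl in place of bromo on an aromatic carbon). Going by the values given here, no measured step exists to guide the size of this change, and the only anchor is compound 2 at 117000 nM in this assay. The expected step, a 1.5-fold lower number from compound 2 to compound 3 (0.17 log units; within the scatter), is estimated to stay within the usual scatter, with no firm direction. A result without a number also remains possible, as compound 1 with "not active" (no number reported) shows. In this assay compound 3 is estimated at 80000 nM (expected range 20000 nM to 250000 nM).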

Compound 3, half-maximal inhibitory concentration: 89600 nM
For compound 3 the middle estimate is 1.1-fold (0.05 log units) below the measured one, within the range that was stated.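

In this assay the exchange of bromo for acetyl on an aromatic carbon, para to a large group, gives a 1.3-fold lower number from compound 2 to compound 3 (0.12 log units; within the scatter) and so leaves the two compounds indistinguishable. The position thus takes acetyl, with three heavy atoms against the single bromine and one hydrogen-bond acceptor where bromo has none, without a step beyond the scatter. No measurement at hand bears on why these two groups read alike.

The compounds shown leave open whether an amine or a carboxylic acid at this same position would give a step beyond the scatter. They also leave open whether any group here can bring the number far from that of compound 2, or whether this position has little bearing on the read-out at all.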